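The source may hold more compounds than are shown below. What is called first, only, known or untested is meant among the compounds shown, and "the series" means these compounds.

Going by the values given here, in a functional assay on MCF7 cells (Homo sapiens) for cytotoxicity, read by MTT assay, with a stated time of 7 days (a lower number here means that less compound is needed, a higher number that more compound is needed for the effect), compound 1 `CC1=C[C@H]2[C@@H](C(C)C)CC[C@@](C)(O)[C@H]2CC1=O` gives 12.9 ug/mL and holds the lower of the two numbers measured so far. Compound 2 `CC(C)[C@@H]1CC[C@@](C)(O)[C@]2(O)[C@@H](O)C[C@@H](C)C[C@@H]12` gives 41.1 ug/mL, a higher number by a margin beyond the usual scatter. Compound 3 `CC1=C[C@@H]2[C@@H](CC1=O)[C@](C)(O)CC[C@H]2C(C)C` is still unmeasured. Among the compounds with values here, as drawn, the two compounds have the same atoms and bonds and differ only in configuration as drawn: 2 of 4 stereo elements differ; a stereocentre at a saturated ring carbon is drawn S in compound 1 and R in compound 3; a stereocentre at a saturated ring carbon is drawn R in compound 1 and S in compound 3 is all that separates it from compound 1: the atoms and bonds are the same, a stereocentre at a saturated ring carbon goes from S to R, and another goes from R to S. No measured pair here shows what such a change does in this assay, so the direction remains open. A step of a 1.4-fold higher number from compound 1 to compound 3 (0.14 log units; within the scatter) is expected, leaning slightly toward a higher number but not beyond the scatter. In this assay compound 3 is estimated at 18 ug/mL with 7 ug/mL to 45 ug/mL as its expected range.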

Compound 3, concentration for half-maximal effect: 30.1 ug/mL
Compound 3: middle estimate off by 1.7-fold (0.22 log units), on the low side, within the range that was stated.
By their numbers in this assay, from the lowest: compound 1; then compounds 3 and 2 (each within the scatter of the next).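

In this assay, going by these compounds alone, this pair gives the first reading of what a change of configuration alone does on the shared core, with two saturated ring carbons inverted together: a 2.3-fold higher number from compound 1 to compound 3 (0.37 log units; beyond the scatter). Within the data shown here, the direction left open before is therefore settled for this pair, as the arrangement drawn in compound 1 needs less compound for the effect than the one drawn in compound 3. The step can be put down to configuration and to nothing else, since no atom or bond changes: the fact that compounds 1 and 3 differ only in the configuration as drawn.

Because both stereocentres change at once, the compounds shown do not tell whether one of them carries the step or both share it. Going by these compounds, what an amine or a carboxylic acid on the shared core would do in this assay also remains open.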